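Chloro-to-hydrogen step on the purine-bearing series

The compounds below may be only part of what the source reports. "The series", "measured", "known", "first", "only" and "open" are said of these compounds alone.

Compound 1 `ClCc1ccc(Cn2cnc3nc(Cl)nc(Cl)c32)cc1`, compound 2 `ClCc1ccccc1Cn1cnc2ncnc(Cl)c21` and compound 3 `ClCc1ccccc1Cn1cnc2nc(Cl)nc(Cl)c21` have been measured in a functional assay on NCI-H522 cells (Homo sapiens) for cytotoxicity, read by sulforhodamine B assay, with a stated time of 48 h; on this read-out lower numbers stand for stronger inhibition of growth and higher numbers for weaker inhibition of growth. Compound 1 gives 1770 nM, compound 2 gives 2810 nM and compound 3 gives 2950 nM; all three values sit within the scatter of one another, so no ordering is drawn from them. Compound 3 and compound 2 differ in one place, (hydrogen in place of chloro on an aromatic carbon), and this change gave a 1.0-fold lower number from compound 3 to compound 2 (0.02 log units; within the scatter). Compound 1 and compound 3 carry the same atoms joined differently; the difference between the two cores is not broken down here.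

Compound 4 `ClCc1ccc(Cn2cnc3ncnc(Cl)c32)cc1` has not been measured. It stands to compound 1 as compound 2 stands to compound 3: the change is hydrogen in place of chloro on an aromatic carbon, with the place described in the same words in both cases, so it is the same change. Because the measured instance of this change gave a 1.0-fold lower number from compound 3 to compound 2 (0.02 log units; within the scatter), the step from compound 1 to compound 4 in this assay is expected to be small, about a 1.0-fold higher number from compound 1 to compound 4 (0.01 log units; within the scatter). Compound 4 is therefore estimated at 1800 nM, with a likely range from 900 nM to 3600 nM.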

Compound 4, concentration for 50% growth inhibition: 4260 nM
The estimate for compound 4 lay 2.4-fold (0.37 log units) below the measured number, and the stated range ends below it.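

In this assay the change of chloro to hydrogen on the aromatic carbon between two ring nitrogen atoms gives a 2.4-fold higher number from compound 1 to compound 4 (0.38 log units; beyond the scatter) on the core of compound 1, a modest step that lies beyond the scatter, whereas the step printed for the other core lies within it. Set side by side, the two steps do not separate, so the series gives no ground for saying that the change behaves differently on the two cores: the same change on two cores in this assay, a 1.0-fold lower number (0.02 log units; within the scatter) from compound 3 to compound 2 and a 2.4-fold higher number (0.38 log units; beyond the scatter) from compound 1 to compound 4, 2.5-fold (0.40 log units) apart, within the scatter of two such steps. Among these compounds, with only two pairs, neither a constant step across cores nor one that depends on the core is established, and these numbers give no reason for the size of either step.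

Left open is how other groups would behave at this place on either core, for instance an amine or a methoxy group in place of the chloro group between two ring nitrogen atoms. Also open, as far as these compounds go, is whether a hydroxymethyl group in place of the chloromethyl group would shift the growth inhibition on either core.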